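This account rests on a few compounds, and the source may have more. Where it says the series, first, only, none or still open, it means among the compounds named here.

Compound 1 `COc1cccc(S(=O)(=O)NC2=NCCN2C(=S)SN2CCn3c2nsc3=S)c1` stands only at a limit: in a functional assay on KYSE-510 cells (Homo sapiens) for antiproliferative activity, read by crystal violet staining, with a stated time of 96 h (a lower number here means a stronger inhibitor of growth, a higher number a weaker inhibitor of growth), compound 1 gives >= 20000 nM, which is a limit of the assay and not a number. Compound 2 `O=S(=O)(NC1=NCCN1C(=S)SN1CCn2c1nsc2=S)c1cc(Cl)cc(Cl)c1` likewise sits at a limit, showing in this assay a value of >= 20000 nM. The step that the two limits leave unreadable from compound 1 to compound 2 therefore cannot be read, since (the limit of >= 20000 nM in this assay, at which 2 of the 2 values shown sit). Compound 3 `O=S(=O)(NC1=NCCN1C(=S)SN1CCn2c1nsc2=S)c1ccc2ccccc2c1` differs from compound 1 by naphthalen-2-yl in place of 3-methoxyphenyl on a sulfonyl sulfur. No readable step bears on this change, and no direction can be drawn from the two limits. Compound 3 is expected to give an estimated 20000 nM, within 8000 nM to 40000 nM. This means an expected step of a number no higher from compound 1 to compound 3 (the limit leaves the size open) of no readable size.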

Compound 3, concentration for 50% growth inhibition: >= 20000 nM
Compound 3: a limit, no number; the forecaster's own chance of this, stated with the estimate: 70%; the middle value lies on the limit itself.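

No new step can be read from compound 1 to compound 3 or from compound 2 to compound 3, because all three compounds sit at a limit: the limit of >= 20000 nM in this assay, at which 3 of the 3 values shown sit.

The compounds shown leave open how strongly each inhibits growth in this assay and whether the group on the sulfonyl sulfur changes this at all.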